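Swapping 4-chlorobenzyl for 2,6-difluorobenzyl on the shared core

The source may report more compounds than this note shows. Statements on the series, on what has been measured and on what is new or still open speak of the compounds shown alone.

Compound 1 `Brc1cccc(CSc2nnc(-c3cnccn3)n2-c2ccccc2)c1`: 9580 nM
Compound 2 `Fc1ccc(CSc2nnc(-c3cnccn3)n2-c2ccccc2)cc1`: 7300 nM
Compound 3 `Clc1ccc(CSc2nnc(-c3cnccn3)n2-c2ccccc2)cc1`: > 50000 nM (a limit, not a number)

All three results come from a functional assay on HeLa cells (Homo sapiens) for antiproliferative activity, read by MTT assay, with a stated time of 48 h; a lower number here means a stronger inhibitor, a higher number a weaker inhibitor. Compound 3 has only a limit in this assay, > 50000 nM. Its place on the scale is the limit of > 50000 nM in this assay, at which 1 of the 3 values shown sits.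

Compound 4 `Fc1cccc(F)c1CSc1nnc(-c2cnccn2)n1-c1ccccc1` keeps the shared core and differs from compound 3 in one place: 2,6-difluorophenyl in place of 4-chlorophenyl on a saturated chain carbon bound to a sulfur. Put simply, 2,6-difluorophenyl stands in place of 4-chlorophenyl on a saturated chain carbon bound to a sulfur.

Among the compounds with values here, two measured steps bear most directly on this change: an at least 6.8-fold higher number from compound 2 to compound 3 (0.83 log units; beyond the scatter), and an at least 5.2-fold higher number from compound 1 to compound 3 (0.71 log units; beyond the scatter). Both lie beyond the scatter, whereas a 1.3-fold lower number from compound 1 to compound 2 (0.12 log units; within the scatter) stays within it. Within the data shown here, no measured compound carries the 2,6-difluorophenyl group. Compound 2, at 7300 nM, is the closest guide, since it also has fluoro on that ring. A move to a lower number in this assay is therefore expected, of about the size of those two steps run in reverse. Since compound 3 has only a limit, that size can be stated only as a bound. The expected change is an at least 5.0-fold lower number from compound 3 to compound 4 (0.69 log units; beyond the scatter). For compound 4 the estimated value is 10000 nM, with an expected range from 4000 nM to 35000 nM.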

Compound 4, half-maximal inhibitory concentration: > 50000 nM
Compound 4: only a limit was reported (the forecaster's own chance of this, stated with the estimate: 15%); middle value at least 5.0-fold (0.69 log units) away from the limit.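

In this assay, having fluoro on the ring does not by itself keep a measurable result at this place on a saturated chain carbon bound to a sulfur: 2,6-difluorophenyl in place of 4-fluorophenyl gives an at least 6.8-fold higher number from compound 2 to compound 4 (0.83 log units; beyond the scatter) and so departs from the compound that looked closest. The same group in place of 3-bromophenyl gives an at least 5.2-fold higher number from compound 1 to compound 4 (0.71 log units; beyond the scatter) and thus places 2,6-difluorophenyl with 4-chlorophenyl, while compound 1 and compound 2 remain the only two of the four with a measured number. The step from 4-chlorobenzyl to 2,6-difluorobenzyl itself cannot be read, since compound 3 and compound 4 both rest on a limit and not on a number: the limit of > 50000 nM in this assay, at which 2 of the 4 values shown sit.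

From the compounds shown here alone, how far compound 3 and compound 4 lie beyond that limit stays unknown, so no order between them can be given. Going by these compounds, it also remains open what an unsubstituted benzyl group or a 4-methoxybenzyl group would give at this place, and whether a 2-fluorobenzyl group would behave like compound 2 or like compound 4.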